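The compounds below may be only part of what the source reports. "The series", "measured", "known", "first", "only" and "open" are said of these compounds alone.

Of the compounds shown here, two have been measured in a functional assay on DU-145 cells (Homo sapiens) for inhibition, read by trypan blue exclusion, with a stated time of 96 h; on this read-out lower numbers stand for stronger inhibition of growth and higher numbers for weaker inhibition of growth. Compound 1 `O=C(O)c1ccc(C(=O)/C(=C\c2ccc(Br)c([N+](=O)[O-])c2)SCc2ccccc2Cl)cc1` gives 1000 nM, and compound 2 `CN(C)c1ccc(/C=C(/SCc2ccc(Cl)cc2)C(=O)c2ccc(C(=O)O)cc2)cc1` gives 1000 nM, so compound 2 stands level with compound 1 at the digits reported. The next compound, compound 3 `O=C(O)c1ccc(C(=O)/C(=C\c2ccc(Br)c([N+](=O)[O-])c2)SCc2ccc(Cl)cc2)cc1`, is reached from compound 2 by putting 4-bromo-3-nitrophenyl in place of 4-(dimethylamino)phenyl on a double-bonded chain carbon bound to a double-bonded chain carbon. For the measured compounds named here, no measured step between compounds that differ in one place is available to size this change. Going by the values given here, the only guide is that compound 1 at 1000 nM and compound 2 at 1000 nM lie within the scatter of each other, so no step beyond the scatter is expected in either direction. The expected step is no change at the digits printed from compound 2 to compound 3 (within the scatter). For compound 3 the estimated value is 1000 nM, with an expected range of 300 nM to 3000 nM.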

Compound 3, concentration for 50% growth inhibition: < 1000 nM
Compound 3: a limit, no number; the forecaster's own chance of this, stated with the estimate: 10%; the middle value lies on the limit itself.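

In this assay, compound 3 carries a limit of the assay and not a number: the limit of < 1000 nM in this assay, at which 1 of the 3 values shown sits. The sizes of the steps to compound 3 from compound 2 and from compound 1 cannot be read, so neither 4-bromo-3-nitrophenyl in place of 4-(dimethylamino)phenyl nor 4-chlorophenyl in place of 2-chlorophenyl can be given a magnitude. For the compounds shown here, still, these pairs are the first that differ in one place, which the earlier compounds could not show: 4-bromo-3-nitrophenyl in place of 4-(dimethylamino)phenyl gives a number no higher from compound 2 to compound 3 (the limit leaves the size open), and 4-chlorophenyl in place of 2-chlorophenyl gives a number no higher from compound 1 to compound 3 (the limit leaves the size open).

On these data alone, how far compound 3 lies from its limit stays open, and so does which of the two changes would count for more if both were sized. Also open, as far as these compounds go, is what a methyl ester or an amide in place of the carboxylic acid would give.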